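Ester group change on compound 1 in this series

The compounds below may be only part of what the source reports. "The series", "measured", "known", "first", "only" and "open" are said of these compounds alone.

Measured compounds in an assay on membranes from CHO cells for displacement of a labelled ligand from adenosine receptor A1 (Homo sapiens), read by scintillation counting, with a stated time of 60 min, tested at 1 uM; a higher number here means more inhibition at the concentration tested (going by the name of the read-out), a lower number less inhibition:
compound 1, `CC1=C(C(=O)OC(C)(C)C)C(c2cccs2)NC(=O)N1`: 26%
compound 2, `CC1=C(C(=O)OC(C)(C)C)C(c2cccs2)NC(=O)N1C`: 18%

Compound 1 stands highest of the two numbers in this assay, with compound 2 nearest; the step of a number 8 percentage points lower from compound 1 to compound 2 (within the scatter) is within the scatter. That one measured step concerns methyl in place of hydrogen on an amide-type nitrogen in a ring and leaves the ester untouched.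

Compound 3, `CC1=C(C(=O)OCC2CC2)C(c2cccs2)NC(=O)N1`, differs from compound 1 by cyclopropylmethyl in place of tert-butyl on an oxygen next to a carbonyl group. Among the compounds with values here, no measured step bears on a change at the oxygen next to the carbonyl group, so the expectation rests on compound 1 alone, 26%, and on the observation that the only change tried so far moved the number by less than the scatter. The step is expected to be a number 2 percentage points lower from compound 1 to compound 3 (within the scatter), which is no step beyond the scatter. Compound 3 is therefore estimated at 24%, within 8% to 42%.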

Compound 3, a percentage reported as inhibition, at one concentration (the size of the read-out at that concentration, not a potency): 23%
Compound 3: middle estimate off by 1 percentage points, on the high side; the measured number falls inside the stated range.
By their numbers in this assay, from the lowest: compounds 2, 3 and 1 (each within the scatter of the next).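

In this assay, cyclopropylmethyl in place of tert-butyl on an oxygen next to a carbonyl group gives a number 3 percentage points lower from compound 1 to compound 3 (within the scatter), so the ring that enters with the new group and the loss of tert-butyl come with no step beyond the scatter. With a number 8 percentage points lower from compound 1 to compound 2 (within the scatter) alongside it, neither of the two places changed on compound 1 has yet given a step beyond the scatter, and the ester now joins the amide-type nitrogen in a ring in that respect. No measurement at hand offers an explanation for this result.

Open, on these data alone, is whether a longer chain or a benzyl group on this oxygen, or a carboxylic acid or an amide in place of the ester, would move the number beyond the scatter. Also open, as far as these compounds go, is whether an amine carried on the cyclopropylmethyl group would do so.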